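Phenyl for cyclohexyl on a quinoline amide series

The source may hold more compounds than are shown below. What is called first, only, known or untested is meant among the compounds shown, and "the series" means these compounds.

Compound 1, `CCCc1cc(N2CCCC2)c2cc(NC(=O)/C=C/c3ccc(C(F)(F)F)cc3)ccc2n1`, gives 17 nM in an assay on isolated protein for displacement of a labelled ligand from melanin-concentrating hormone receptor 1 (Homo sapiens); a lower number here means a stronger inhibitor, a higher number a weaker inhibitor. Compound 2, `Nc1cc(C2CCCCC2)nc2ccc(NC(=O)/C=C/c3ccc(C(F)(F)F)cc3)cc12`, gives 1.2 nM in this assay. Compound 3, `CCCc1cc(N)c2cc(N(C)C(=O)CCc3ccc(C(F)(F)F)cc3)ccc2n1`, gives 1700 nM in this assay.

Of the three, compound 2 carries the lowest number, with compound 1 nearest and compound 3 furthest; both separations are beyond the scatter, so compound 2 is the most potent of the set as measured. No two of these compounds differ in only one place, so no single step can be read off among them.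

Compound 4, `Nc1cc(-c2ccccc2)nc2ccc(NC(=O)/C=C/c3ccc(C(F)(F)F)cc3)cc12`, is not yet measured. It is made from compound 2 by phenyl in place of cyclohexyl on an aromatic carbon. Among the measured compounds shown here, the data hold no step of this kind, so the expectation rests on compound 2 alone. The step of a 2.1-fold higher number from compound 2 to compound 4 (0.32 log units; beyond the scatter) is expected to be small, at most a modest weakening that may not exceed the scatter. Compound 4 is therefore expected near 2.5 nM in this assay. Compound 4 is estimated to fall between 0.6 nM and 12 nM.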

Compound 4, half-maximal inhibitory concentration: 18.5 nM
Estimate against measurement, compound 4: 7.4-fold (0.87 log units) below; the whole stated range lies below it.
By their numbers in this assay, from the lowest: compound 2; then compounds 1 and 4 (each within the scatter of the next); then compound 3.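

In this assay, among the compounds shown here, phenyl in place of cyclohexyl on the aromatic carbon next to the ring nitrogen gives a 15-fold higher number from compound 2 to compound 4 (1.19 log units; beyond the scatter), so this position is sensitive to the nature of its six-membered ring, which the earlier compounds, with no single step among them, could not show. The two groups match in their count of heavy atoms, and neither has hydrogen-bond donors or acceptors; the difference that the structures print is a non-aromatic ring against an aromatic one. Nothing measured here bears on why the number rises.

The compounds shown leave open how this position responds to other groups, such as cyclopentyl, tert-butyl or pyridyl. They also leave open whether the same change would give a step of this size with a pyrrolidine in place of the amino group.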